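Fluorinated aryl variants on a shared core: antiproliferative notes

This account rests on a few compounds, and the source may have more. Where it says the series, first, only, none or still open, it means among the compounds named here.

Measured so far:
compound 1, `OC[C@H]1O[C@@H](n2cnc3c(NCc4ccc(F)cc4)ncnc32)[C@H](O)[C@@H]1O`: in a functional assay on G-361 cells (Homo sapiens) for antiproliferative activity, with a stated time of 72 h (a higher number here means a weaker inhibitor, a lower number a stronger inhibitor), compound 1 gives > 166000 nM, a limit of the assay rather than a number.
compound 2, `OC[C@H]1O[C@@H](n2cnc3c(NCc4cccc(C(F)(F)F)c4)ncnc32)[C@H](O)[C@@H]1O`: in this assay compound 2 gives > 166000 nM, likewise a limit and not a number.

Compound 2 therefore stands at the limit of this assay, and the other value shown is a limit as well, so there is no number to rank it against; both readings sit at the limit of > 166000 nM in this assay, at which 2 of the 2 values shown sit. Among the measured compounds shown here, the one measured step, a step that the two limits leave unreadable from compound 1 to compound 2, cannot be read because both ends are limits.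

Compound 3, `OC[C@H]1O[C@@H](n2cnc3c(NCc4ccc(C(F)(F)F)cc4)ncnc32)[C@H](O)[C@@H]1O`, differs from compound 2 in one place: 4-(trifluoromethyl)phenyl in place of 3-(trifluoromethyl)phenyl on a saturated chain carbon bound to a nitrogen on an aromatic ring. For the measured compounds named here, the only measured step that bears on this change is the unreadable one from compound 1 to compound 2, so no size or direction can be taken from it.

Given that compound 2 and compound 1 both reached only the limit, compound 3 is expected to stay at or beyond that limit too, with an estimate of 200000 nM and a range of 100000 nM to 600000 nM. The step this estimate implies for compound 3 is a step that the limit leaves unreadable from compound 2 to compound 3, meaning no change is expected beyond the scatter.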

Compound 3, half-maximal inhibitory concentration: > 166000 nM
Compound 3 was reported as a limit; the forecaster's own chance of this, stated with the estimate: 90%; the middle value is on the limit's open side.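

In this assay compound 3 gives > 166000 nM, a limit and not a number. The steps from compound 1 and compound 2 to compound 3 therefore cannot be read: the limit of > 166000 nM in this assay, at which 3 of the 3 values shown sit.

The compounds shown leave open whether 4-fluorophenyl, 3-(trifluoromethyl)phenyl and 4-(trifluoromethyl)phenyl on the shared core differ at all in this assay.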